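The source may report more compounds than this note shows. Statements on the series, on what has been measured and on what is new or still open speak of the compounds shown alone.

Three compounds have been tested in a functional assay on HT-29 cells (Homo sapiens) for cytotoxicity, read by MTT assay, with a stated time of 24 h, tested at 80 ug/mL; on this read-out lower numbers stand for a weaker effect and higher numbers for a stronger effect at the one concentration tested:

compound 1, `Cn1c(-c2ccc(NC(=O)CCl)cc2)nc(-c2ccccc2)c1-c1ccccc1`, gives 76.1%
compound 2, `Cc1ccc2oc(SCC(=O)Nc3ccc(-c4nc(-c5ccccc5)c(-c5ccccc5)n4C)cc3)nc2c1`, gives 69.8%
compound 3, `CCN1CCN(CC(=O)Nc2ccc(-c3nc(-c4ccccc4)c(-c4ccccc4)n3C)cc2)CC1`, gives 51.2%

Compound 1 has the highest of these three numbers, though compound 2 lies within the scatter of it, while compound 3 lies beyond it. The unmeasured compound 4, `Cn1c(-c2ccc(NC(=O)CN3CCN(c4ccccc4)CC3)cc2)nc(-c2ccccc2)c1-c1ccccc1`, departs from compound 1 in one place: 4-phenylpiperazin-1-yl in place of chloro on a saturated chain carbon bound to a carbonyl carbon. Two measured steps leave the same chloro from the same place. Replacing it with a ring-bearing sulfanyl group changed little, a number 6.3 percentage points lower from compound 1 to compound 2 (within the scatter), whereas replacing it with a piperazine ring bearing an ethyl group lowered the read-out modestly, a number 24.9 percentage points lower from compound 1 to compound 3 (beyond the scatter). Compound 4 also carries a piperazine ring at that place, now bearing a phenyl group instead, so a modest drop in this assay is expected, though likely not larger than that seen for compound 3. The estimated step is a number 18.1 percentage points lower from compound 1 to compound 4 (beyond the scatter). Compound 4 is therefore expected to give about 58%, with a range from 42% to 74%.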

Compound 4, a percentage reported as activity, at one concentration (the size of the read-out at that concentration, not a potency): 63.7%
Beside the measured number, compound 4's estimate is 5.7 percentage points below it; the range from low to high includes it.
By their numbers in this assay, from the lowest: compound 3; then compounds 4, 2 and 1 (each within the scatter of the next, the first and the last beyond it).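

In this assay the group carried by the piperazine ring turns out to matter at this place: phenyl in place of ethyl on an amine nitrogen in a ring gives a number 12.5 percentage points higher from compound 3 to compound 4 (beyond the scatter) and so the piperazine ring alone does not fix the read-out. Chloro still stands apart from the phenyl-bearing group, since 4-phenylpiperazin-1-yl in place of chloro gives a number 12.4 percentage points lower from compound 1 to compound 4 (beyond the scatter) while 4-phenylpiperazin-1-yl in place of (5-methyl-1,3-benzoxazol-2-yl)sulfanyl gives a number 6.1 percentage points lower from compound 2 to compound 4 (within the scatter) and so these two ring-bearing groups cannot be told apart here. Nothing measured here explains the difference between phenyl and ethyl.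

Still open, going by these compounds, is whether a benzyl group or a pyridine ring on the piperazine would behave like phenyl or like ethyl. Also open, on these data alone, is whether a morpholine ring on the saturated chain carbon would match the piperazines.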